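Swapping the Aryl Group of a Folate Enzyme Inhibitor

This account rests on a few compounds, and the source may have more. Where it says the series, first, only, none or still open, it means among the compounds named here.

Compound 1 `NC1=NC2(CCSCC2)N(OCCCOc2ccc(Cl)c(Cl)c2)C(N)=N1` was tested in an assay on isolated protein for inhibition of Dihydrofolate reductase (Homo sapiens), read by spectrophotometry, using NADPH, with stated times of 5 s and 6 min, tested at 5 uM (a lower number here means a weaker effect, a higher number a stronger effect of the compound at the concentration tested), where compound 1 gives 88.4%. For the measured compounds named here, that is the only plain number in this small set. Compound 2 `NC1=NC2(CCOCC2)N(OCCCOc2ccc(F)cc2)C(N)=N1` was measured in the same way. In this assay compound 2 gives > 90%, which is a limit of the assay rather than a number. One of the two values shown sits at that limit (the limit of > 90% in this assay, at which 1 of the 2 values shown sits). Compound 1 and compound 2 differ in more than one place, so their two values show only that both inhibit strongly at the concentration tested.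

Compound 3 `COc1ccc(OCCCON2C(N)=NC(N)=NC23CCSCC3)cc1` has not yet been measured. It differs from compound 1 in one place (4-methoxyphenyl in place of 3,4-dichlorophenyl on an oxygen on a saturated carbon); the entering group carries one hydrogen-bond acceptor where the leaving group had none. Going by the values given here, no measured pair shows what such a swap does here. Compound 1 already gives a high reading of 88.4%, so only a small step, within the usual scatter, is expected. Compound 3 is therefore expected to give 85%, somewhere between 68% and 95%. The expected step from compound 1 to compound 3 is a number 3.4 percentage points lower from compound 1 to compound 3 (within the scatter) in this assay.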

Compound 3, a percentage reported as inhibition, at one concentration (the size of the read-out at that concentration, not a potency): 81.3%
Beside the measured number, compound 3's estimate is 3.7 percentage points above it, and the stated range covers the measured number.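

For the compounds shown here, the swap of 3,4-dichlorophenyl for 4-methoxyphenyl on an oxygen on a saturated carbon is the first change in this set that can be read on its own, and in this assay it gives a number 7.1 percentage points lower from compound 1 to compound 3 (within the scatter). At this position, then, a ring with no chlorine and with a hydrogen-bond acceptor in the entering group gives a reading that cannot be told apart from that of the dichlorinated ring, at least at the single concentration tested. Compound 2 gives a limit of the assay rather than a number, so it adds no further step here: the limit of > 90% in this assay, at which 1 of the 3 values shown sits.

Going by these compounds, a reading at one concentration is not a potency, so any real difference between compound 1 and compound 3 in how much compound is needed for the same inhibition remains unknown. The compounds shown also leave open how far this position tolerates change, for instance a plain unsubstituted phenyl, a ring carrying a carboxylic acid or an amine, or a longer chain between the oxygen atoms.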